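Swapping a Halogenated Ring for a Dimethoxyphenyl Ring

The source may hold more compounds than are shown below. What is called first, only, known or untested is meant among the compounds shown, and "the series" means these compounds.

Among the compounds with values here, compound 1 `Cc1oc(-c2c(Cl)cccc2Br)nc1CN1CCC(C(=O)NCCCN2C[C@H](C)C[C@H](C)C2)CC1` stands at the low end of the two numbers so far in an ADME assay on microsomes from liver (Rattus norvegicus) for metabolic stability, read by LC-MS, using NADPH, at 37 degrees C; a lower number here means that the compound disappears faster, a higher number that the compound lasts longer: compound 1 gives 0.0233 h, while compound 2 `Cc1cccc(Cl)c1-c1nc(CN2CCC(C(=O)NCCCN3CCCC(C)C3)CC2)c(C)o1` gives 0.09 h, and that gap lies beyond the usual scatter. Compound 3 `COc1ccc(-c2nc(CN3CCC(C(=O)NCCCN4C[C@H](C)C[C@H](C)C4)CC3)c(C)o2)cc1OC` has not yet been measured. It differs from compound 1 in a single place: 3,4-dimethoxyphenyl in place of 2-bromo-6-chlorophenyl on an aromatic carbon. Within the data shown here, no measured pair shows what this particular exchange does in this assay, so the two measured values only show that compound 1 is the shorter-lived of the two. With nothing more to go on, the step from compound 1 to compound 3 is expected to be modest, a 1.3-fold higher number from compound 1 to compound 3 (0.11 log units; within the scatter), and may well fall inside the scatter in either direction. For compound 3 the estimated half-life in this assay is 0.03 h, with a range from 0.01 h to 0.12 h.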

Compound 3, half-life: > 0.5 h
Compound 3: only a limit was reported; the forecaster's own chance of this, stated with the estimate: 10%; middle value at least 16-fold (1.22 log units) from the limit.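

Within the data shown here, the first pair of compounds that differ in only one place shows that the group on this aromatic carbon of the five-membered ring can strongly affect how long a compound lasts in this assay: 3,4-dimethoxyphenyl in place of 2-bromo-6-chlorophenyl gives an at least 21-fold higher number from compound 1 to compound 3 (1.33 log units; beyond the scatter). The rest of the structure is the same in this pair, so this one exchange accompanies the whole step. The result for compound 3, > 0.5 h, is a limit and not a number, so the step has no known upper end: the limit of > 0.5 h in this assay, at which 1 of the 3 values shown sits.

The exchange removes the bromine and chlorine and adds two methoxy groups in a single step, so the compounds shown cannot separate the effects of these changes. Going by these compounds, how a phenyl ring carrying one methoxy group, or no substituent at all, would behave on this carbon also remains open.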